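The source may hold more compounds than are shown below. What is called first, only, known or untested is meant among the compounds shown, and "the series" means these compounds.

Compound 1 `O=[N+]([O-])c1cn2c(n1)OC(COc1ccc(-c3ccc(F)nc3F)nc1)CC2`: in an ADME assay on MRC5 cells (Homo sapiens) for cytotoxicity, read by resazurin assay, with a stated time of 72 h (on this read-out lower numbers stand for stronger inhibition and higher numbers for weaker inhibition), compound 1 gives > 64000 nM, which is a limit of the assay and not a number.
Compound 2 `CC1(COc2ccc(-c3ccc(F)nc3F)nc2)CCn2cc([N+](=O)[O-])nc2O1`: compound 2 gives > 64000 nM, again a limit.
Compound 3 `CC1(COc2cccc(-c3ccc(F)cc3)n2)CCn2cc([N+](=O)[O-])nc2O1`: compound 3 gives > 64000 nM, also a limit.

The change from compound 2 to compound 1 is hydrogen in place of methyl on a saturated ring carbon. Its effect is a step that the two limits leave unreadable from compound 2 to compound 1, since every value here rests at the limit of > 64000 nM in this assay, at which 3 of the 3 values shown sit. How the core of compound 2 differs from the core of compound 3 is not broken down here.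

Compound 4 `O=[N+]([O-])c1cn2c(n1)OC(COc1cccc(-c3ccc(F)cc3)n1)CC2` is not yet measured. It differs from compound 3 by hydrogen in place of methyl on a saturated ring carbon; the place described is the same, word for word, as for the change from compound 2 to compound 1, so this is the same change. The step is expected to be a step that the limit leaves unreadable from compound 3 to compound 4, because the earlier step of this kind sat at the limit of > 64000 nM in this assay, at which 3 of the 3 values shown sit. Compound 4 is therefore estimated at 80000 nM, most likely reported again only as a limit.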

Compound 4, half-maximal inhibitory concentration: 59000 nM
For compound 4 the middle estimate is 1.4-fold (0.13 log units) above the measured one; the range from low to high includes it.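

In this assay, putting hydrogen in place of methyl on a saturated ring carbon gives an at least 1.0-fold lower number from compound 3 to compound 4 (0.03 log units; that floor lies within the scatter), so the change on this core shows no firm shift in either direction. Compound 3 gives > 64000 nM, which is a limit of the assay and not a number. The result does not show that the change behaves alike on both cores, because the step from compound 2 to compound 1 cannot be read: the limit of > 64000 nM in this assay, at which 3 of the 4 values shown sit.

The compounds shown leave open what a longer chain, an amine or a carboxylic acid on that saturated ring carbon would do in this assay. They also leave open how large the step on either core really is.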